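The source may hold more compounds than are shown below. What is called first, only, known or untested is meant among the compounds shown, and "the series" means these compounds.

Measured so far in an assay on membranes from striatum (strain Sprague-Dawley) for displacement of a labelled ligand from sodium-dependent dopamine transporter (Rattus norvegicus), read by scintillation counting, with a stated time of 120 min; on this read-out higher numbers stand for weaker inhibition and lower numbers for stronger inhibition:
compound 1 `OC(Cc1ccccc1)CN1CCC(NCCSC(c2ccc(F)cc2)c2ccc(F)cc2)CC1`, 31.4 nM
compound 2 `Fc1ccc(C(SCCNC2CCN(Cc3cc4ccccc4[nH]3)CC2)c2ccc(F)cc2)cc1`, 179 nM
compound 3 `Fc1ccc(C(SCCNC2CCN(Cc3cc4ccccc4o3)CC2)c2ccc(F)cc2)cc1`, 120 nM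

Compound 3 stands second highest of the three numbers; its nearest neighbour is compound 2, a step of a 1.5-fold lower number from compound 2 to compound 3 (0.17 log units; within the scatter), and its furthest is compound 1, a step of a 3.8-fold higher number from compound 1 to compound 3 (0.58 log units; beyond the scatter). Compound 4 `O=C(c1ccccc1F)N1CCC(NCCSC(c2ccc(F)cc2)c2ccc(F)cc2)CC1` differs from compound 3 by (2-fluorophenyl)carbonyl in place of (1-benzofuran-2-yl)methyl on an amine nitrogen in a ring. All three measured steps change the group on that same ring nitrogen: a 5.7-fold higher number from compound 1 to compound 2 (0.76 log units; beyond the scatter) and a 3.8-fold higher number from compound 1 to compound 3 (0.58 log units; beyond the scatter) were modest, while a 1.5-fold lower number from compound 2 to compound 3 (0.17 log units; within the scatter) stayed within the scatter. Among the compounds with values here, no measured step swaps a methylene link for a carbonyl, so the expected step of a 2.5-fold higher number from compound 3 to compound 4 (0.40 log units; beyond the scatter) rests loosely on these. Compound 4 is therefore estimated at 300 nM in this assay, with a range from 80 nM to 1200 nM.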

Compound 4, inhibition constant: 46.1 nM
Compound 4: the middle estimate sits 6.5-fold (0.81 log units) above what was measured; the measured number lies below the stated range.
By their numbers in this assay, from the lowest: compounds 1 and 4 (each within the scatter of the next); then compounds 3 and 2 (each within the scatter of the next).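

The amine nitrogen in the ring need not carry a saturated carbon link: with (2-fluorophenyl)carbonyl there, the numbers run a 2.6-fold lower number from compound 3 to compound 4 (0.42 log units; beyond the scatter) and a 3.9-fold lower number from compound 2 to compound 4 (0.59 log units; beyond the scatter), both modest steps, while a 1.5-fold higher number from compound 1 to compound 4 (0.17 log units; within the scatter) stays within the scatter. The hydroxy group of compound 1 is thus not needed to reach this range. Nothing available explains these steps. Going by these compounds, the change swaps the whole group at once, so the part played by the carbonyl and by the fluorine stays open. On these data alone, how (2-fluorophenyl)methyl, unsubstituted benzoyl or a sulfonyl group would read on this nitrogen also stays open.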